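The source may hold more compounds than are shown below. What is called first, only, known or untested is meant among the compounds shown, and "the series" means these compounds.

Compound 3 `CCN(CC)C(=O)C1=C(C)NC(=O)NC1c1cccs1` stands highest among the three compounds measured in an assay on membranes from CHO cells for displacement of a labelled ligand from adenosine receptor A1 (Homo sapiens), read by scintillation counting, with a stated time of 60 min, tested at 1 uM (on this read-out higher numbers stand for more inhibition at the one concentration tested (going by the name of the read-out) and lower numbers for less inhibition), where compound 3 gives 13%. Compound 1 `CCCC(=O)C1=C(C)NC(=O)NC1c1cccs1` gives 2%, and compound 2 `CCNC(=O)C1=C(C)NC(=O)NC1c1cccs1` gives 1%. Compound 4 `CCSC(=O)C1=C(C)NC(=O)NC1c1cccs1` differs from compound 3 at the carbonyl carbon: ethylsulfanyl in place of diethylamino on a carbonyl carbon. For the measured compounds named here, the steps that bear on this site are a number 11 percentage points higher from compound 1 to compound 3 (beyond the scatter) and a number 12 percentage points higher from compound 2 to compound 3 (beyond the scatter), both modest and beyond the scatter, while a number 1 percentage points lower from compound 1 to compound 2 (within the scatter) lies within it. Since the ethylsulfanyl group, like the propyl and ethylamino groups, is smaller than diethylamino, a drop back toward the numbers of compound 1 and compound 2 is expected, so a number 8 percentage points lower from compound 3 to compound 4 (within the scatter) is estimated as a modest fall. Compound 4 is therefore expected to give about 5%, within 0% to 18%.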

Compound 4, a percentage reported as inhibition, at one concentration (the size of the read-out at that concentration, not a potency): 6%
The estimate for compound 4 lay 1 percentage points below the measured number; the range from low to high includes it.
By their numbers in this assay, from the lowest: compounds 2, 1, 4 and 3 (each within the scatter of the next, the first and the last beyond it).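

In this assay ethylsulfanyl on the carbonyl carbon cannot be told apart from any of the other three groups, with a number 7 percentage points lower from compound 3 to compound 4 (within the scatter) and a number 5 percentage points higher from compound 2 to compound 4 (within the scatter) and a number 4 percentage points higher from compound 1 to compound 4 (within the scatter). Compound 4 therefore links the two levels seen earlier, since compound 3 lies beyond the scatter of compound 1 and compound 2 but compound 4 lies beyond the scatter of none of them. No available evidence accounts for this result. Open, as far as these compounds go, is whether a longer chain, such as butylsulfanyl, or a cyclic amine, such as piperidine, on this carbonyl carbon would lie beyond the scatter of compound 3.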